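The compounds below may be only part of what the source reports. "The series", "measured", "known", "first", "only" and "open" are said of these compounds alone.

Measured compounds:
compound 1 `O=[N+]([O-])c1ccc(Cn2cc(COc3ccccc3)nn2)cc1` — > 100 ug/mL
compound 2 `O=[N+]([O-])c1ccc(Cn2cc(COc3ccc(Cl)cc3)nn2)cc1` — > 100 ug/mL

In an ADME assay on PANC-1 cells (Homo sapiens) for inhibition, read by MTT assay, with a stated time of 48 h (a higher number here means a weaker inhibitor of growth, a lower number a stronger inhibitor of growth), compound 1 gives > 100 ug/mL, which is a limit of the assay and not a number. Compound 2 gives > 100 ug/mL in this assay, again a limit. The step that the two limits leave unreadable from compound 1 to compound 2 therefore has no readable size, because both values sit at the limit of > 100 ug/mL in this assay, at which 2 of the 2 values shown sit. Compound 2 thus stands only at a limit in this assay, with no number of its own.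

Compound 3 `Cc1cc(OCc2cn(Cc3ccc([N+](=O)[O-])cc3)nn2)ccc1Cl` differs from compound 2 by methyl in place of hydrogen on an aromatic carbon. Among the measured compounds shown here, the one measured step bears on this change only in showing that both of its compounds reach the limit; it gives no size and no direction, so nothing beyond the scatter can be read from it. Compound 3 is therefore expected to sit near the same limit, with an estimated value of 150 ug/mL, between 60 ug/mL and 400 ug/mL, which means an expected step that the limit leaves unreadable from compound 2 to compound 3.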

Compound 3, concentration for 50% growth inhibition: > 100 ug/mL
Compound 3 ended at the assay's limit (the forecaster's own chance of this, stated with the estimate: 85%); the middle value lies beyond the limit too.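

Among the compounds shown here, no step among compound 1, compound 2 and compound 3 can be read in this assay, because each gives a limit and not a number: the limit of > 100 ug/mL in this assay, at which 3 of the 3 values shown sit. The compounds shown leave open how strongly any of them inhibits growth, and whether chloro or methyl alters it.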